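Trifluoromethyl on the aniline ring across two cores

The source may hold more compounds than are shown below. What is called first, only, known or untested is meant among the compounds shown, and "the series" means these compounds.

Compound 1 `FC(F)(F)c1ccc(NCc2cn(-c3ccccc3)nc2-c2ccc(C(F)(F)F)cc2)cc1` and compound 2 `FC(F)(F)c1ccc(NCc2cn(-c3ccccc3)nc2-c2ccccc2)cc1` share one core, while compound 3 `Cc1ccc(-c2nn(-c3ccccc3)cc2CNc2ccccc2)cc1` and compound 4 `Cc1ccc(-c2nn(-c3ccccc3)cc2CNc2ccc(C(F)(F)F)cc2)cc1` share another; the difference between the two cores is not broken down here. In an ADME assay on BHK-21 cells (Mesocricetus auratus) for cytotoxicity, read by MTT assay, with a stated time of 72 h (on this read-out higher numbers stand for lower toxicity in this test and lower numbers for higher toxicity in this test), compound 1 gives 27000 nM and compound 2 gives 37000 nM. In this assay, among the measured compounds shown here, compound 3 reaches only the limit of > 100000 nM, so no number is known for it, and it is the one value that sits at the limit of > 100000 nM in this assay, at which 1 of the 3 values shown sits.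

The change from compound 2 to compound 1 is trifluoromethyl in place of hydrogen on an aromatic carbon, and it made a 1.4-fold lower number from compound 2 to compound 1 (0.14 log units; within the scatter). Compound 4 carries the same change against compound 3: trifluoromethyl in place of hydrogen on an aromatic carbon.

Given that the measured step gave only a 1.4-fold lower number from compound 2 to compound 1 (0.14 log units; within the scatter) and that compound 3 sits at > 100000 nM, compound 4 is expected to stay near that limit, with the expected step of an at least 1.1-fold lower number from compound 3 to compound 4 (0.04 log units; that floor lies within the scatter). The estimate for compound 4 in this assay is 90000 nM, expected to fall between 40000 nM and 200000 nM, with a fair chance that only a limit is reported again.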

Compound 4, half-maximal cytotoxic concentration: 88000 nM
Beside the measured number, compound 4's estimate is 1.0-fold (0.01 log units) above it, within the range that was stated.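

In this assay trifluoromethyl in place of hydrogen on an aromatic carbon gives an at least 1.1-fold lower number from compound 3 to compound 4 (0.05 log units; that floor lies within the scatter) as a floor only. On these data alone, compound 3 gives > 100000 nM as a limit and not a number, so the true size of that step stays unknown: the limit of > 100000 nM in this assay, at which 1 of the 4 values shown sits. Neither step on the two cores is shown to lie beyond the scatter, yet equal carry-over of the change from one core to the other is not shown either: the same change on two cores in this assay, a 1.4-fold lower number (0.14 log units; within the scatter) from compound 2 to compound 1 and an at least 1.1-fold lower number (0.05 log units; that floor lies within the scatter) from compound 3 to compound 4; the limit leaves it open whether they differ.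

Methyl in place of hydrogen gives a 2.4-fold higher number from compound 2 to compound 4 (0.38 log units; beyond the scatter) and methyl in place of trifluoromethyl gives a 3.3-fold higher number from compound 1 to compound 4 (0.51 log units; beyond the scatter) as modest steps, each resting on a single pair, so whether they hold on another core stays open. Also open, as far as these compounds go, is how this read-out responds to other groups on the same aromatic carbon, such as an amine, a nitrile or a carboxylic acid.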